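The source may report more compounds than this note shows. Statements on the series, on what has been measured and on what is new or still open speak of the compounds shown alone.

In a functional assay on MDA-MB-231 cells (Homo sapiens) for antiproliferative activity, read by sulforhodamine B assay, with a stated time of 72 h (a lower number here means a stronger inhibitor, a higher number a weaker inhibitor), compound 1 `Cc1ccc(S(=O)(=O)Nc2cc(SCC(=O)N[C@@H](CC(C)C)B(O)O)c(O)c3ccccc23)cc1` gives 14000 nM, compound 2 `CC(C)C[C@H](NC(=O)CSc1cc(NS(=O)(=O)c2ccccc2)c2ccccc2c1O)B(O)O` gives 10600 nM, and compound 3 `Cc1ccc(S(=O)(=O)Nc2cc(SCCC(=O)N[C@@H](CC(C)C)B(O)O)c(O)c3ccccc23)cc1` gives 6150 nM. Compound 3 is separated from compound 1 by more than the scatter, whereas the values of compound 3 and compound 2 lie within the scatter of each other.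

The unmeasured compound 4 `CC(C)C[C@H](NC(=O)CCSc1cc(NS(=O)(=O)c2ccccc2)c2ccccc2c1O)B(O)O` differs from compound 3 by a single change, hydrogen in place of methyl on an aromatic carbon, para to a large group, 4-methylphenyl becoming phenyl: hydrogen in place of methyl on an aromatic carbon.

The same replacement has been measured once, as a 1.3-fold lower number from compound 1 to compound 2 (0.12 log units; within the scatter). The other measured step, a 2.3-fold lower number from compound 1 to compound 3 (0.36 log units; beyond the scatter), lies at a different place in the molecule and offers no direct guide to this replacement. With one small precedent to go on, no shift beyond the scatter is expected in this assay, and the estimated step is a 1.2-fold lower number from compound 3 to compound 4 (0.09 log units; within the scatter). Compound 4 is expected at 5000 nM, with an estimated range of 2800 nM to 9000 nM.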

Compound 4, half-maximal inhibitory concentration: 4200 nM
Estimate against measurement, compound 4: 1.2-fold (0.08 log units) above; low and high end bracket the measured number.
By their numbers in this assay, from the lowest: compounds 4, 3, 2 and 1 (each within the scatter of the next, the first and the last beyond it).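

In this assay, the change from 4-methylphenyl to phenyl has now been read on a second core, giving a 1.5-fold lower number from compound 3 to compound 4 (0.17 log units; within the scatter). Among the compounds shown here, until now this change had been seen only on the core of compound 1, so a single small step could have been particular to that core. The second reading agrees with the first, and on both cores the change at this place, para to a large group, stays within the scatter: the same change on two cores in this assay, a 1.3-fold lower number (0.12 log units; within the scatter) from compound 1 to compound 2 and a 1.5-fold lower number (0.17 log units; within the scatter) from compound 3 to compound 4, 1.1-fold (0.04 log units) apart, within the scatter of two such steps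

The compounds shown carry only methyl or hydrogen at this position, so it remains open whether a methoxy group, a chlorine or an amine there would shift the number beyond the scatter. Also open, on these data alone, is whether a longer chain on the sulfur would lower the number further on either the 4-methylphenyl or the phenyl series.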